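The source may report more compounds than this note shows. Statements on the series, on what has been measured and on what is new or still open speak of the compounds shown alone.

Working notes on the series. In a functional assay on cells (T-cell line, Homo sapiens) for inhibition (a higher number here means a weaker inhibitor, a lower number a stronger inhibitor), compound 1 (`COc1ccc(CCCN2CCC(CNC(c3ccccc3)c3ccccc3)CC2)cc1`) gives 2800 nM and compound 2 (`COc1ccc(CCCN2CCC(COCc3ccccc3)CC2)cc1`) gives 2100 nM. These two numbers lie within the scatter of each other, so compound 2 cannot be ranked against compound 1, and both serve as a common starting level for the next comparison.

Compound 3 (`COc1ccc(CCCN2CCC(COCc3ccc(Cl)c(Cl)c3)CC2)cc1`) differs from compound 2 in one place: 3,4-dichlorophenyl in place of phenyl on a saturated chain carbon bound to an oxygen on a saturated carbon.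

Within the data shown here, no measured pair differs in one place, so the data offer no precedent for this change and the expectation is loosely held. A moderate move towards stronger inhibition is expected, a 2.6-fold lower number from compound 2 to compound 3 (0.42 log units; beyond the scatter). For compound 3 the estimated value in this assay is 800 nM, with an expected range of 200 nM to 3000 nM.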

Compound 3, half-maximal inhibitory concentration: 200 nM
Estimate against measurement, compound 3: 4.0-fold (0.60 log units) above, and the stated range covers the measured number.
By their numbers in this assay, from the lowest: compound 3; then compounds 2 and 1 (each within the scatter of the next).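

In this assay, among these compounds, this position on a saturated chain carbon bound to an oxygen on a saturated carbon proves sensitive to what the aromatic ring carries: 3,4-dichlorophenyl in place of phenyl gives an 11-fold lower number from compound 2 to compound 3 (1.02 log units; beyond the scatter) and so provides the first change that can be read beyond the scatter. The level shared by compound 1 and compound 2 had shown no such separation, and this single exchange, which adds only the two chlorine atoms, moves the series well away from that level. Nothing available bears on the reason for the size of this step.

Going by these compounds, it remains open whether a single chlorine would carry the whole step, or whether a methyl, methoxy or trifluoromethyl group on the ring would do the same. On these data alone, it is also open whether 3,4-dichlorophenyl would give a comparable step on the amine side chain of compound 1.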